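Para substituent swap on the pendant phenyl ring

The compounds below may be only part of what the source reports. "The series", "measured", "known", "first", "only" and "open" are said of these compounds alone.

Measured compounds:
- compound 1 `CCCS(=O)(=O)Nc1ccc(F)c(C(=O)c2n[nH]c3ncc(-c4ccccc4)cc23)c1F`: 2.4%
- compound 2 `CCCS(=O)(=O)Nc1ccc(F)c(C(=O)c2n[nH]c3ncc(-c4cccc(N)c4)cc23)c1F`: 1.6%
- compound 3 `CCCS(=O)(=O)Nc1ccc(F)c(C(=O)c2n[nH]c3ncc(-c4ccc(C(F)(F)F)cc4)cc23)c1F`: 29%

Compound 3 stands highest of the three numbers in an assay for binding affinity to dual specificity mitogen-activated protein kinase kinase 4 (Homo sapiens), read by KINOMEscan, tested at 100 nM; a higher number here means a weaker effect of the compound at the concentration tested, a lower number a stronger effect. Its nearest neighbour is compound 1, with a number 26.6 percentage points higher from compound 1 to compound 3 (beyond the scatter); compound 2 sits furthest, with a number 27.4 percentage points higher from compound 2 to compound 3 (beyond the scatter). Going by the values given here, compounds 1 and 2 differ from each other by a number 0.8 percentage points lower from compound 1 to compound 2 (within the scatter), so the only step of note in the set is the one introduced by the trifluoromethyl group on the phenyl ring.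

Compound 4 `CCCS(=O)(=O)Nc1ccc(F)c(C(=O)c2n[nH]c3ncc(-c4ccc(S(C)(=O)=O)cc4)cc23)c1F` has not been measured. It differs from compound 3 by methylsulfonyl in place of trifluoromethyl on an aromatic carbon, placed on an aromatic carbon of a six-membered aromatic ring of carbon only, para to a large group.

Among the compounds with values here, no measured step swaps one para substituent for another, so the bearing evidence is indirect: the two steps into compound 3 show that a para group on this ring can move the number beyond the scatter, and both were of modest size. On these data alone, whether methylsulfonyl behaves like trifluoromethyl or like hydrogen here is unknown. A step back toward the unsubstituted values is expected as a middle case, of size a number 14 percentage points lower from compound 3 to compound 4 (beyond the scatter). Compound 4 is therefore estimated at 15%, within 2% to 50%.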

Compound 4, a percentage reported as activity, at one concentration (the size of the read-out at that concentration, not a potency): 1.5%
Beside the measured number, compound 4's estimate is 13.5 percentage points above it; measured number below the stated range.
By their numbers in this assay, from the lowest: compounds 4, 2 and 1 (each within the scatter of the next); then compound 3.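

In this assay, the aromatic carbon para to a large group now has a direct swap of one substituent for another, a number 27.5 percentage points lower from compound 3 to compound 4 (beyond the scatter), which shows that the raised number of compound 3 goes with trifluoromethyl and not with every group placed there. The step from hydrogen to methylsulfonyl reads a number 0.9 percentage points lower from compound 1 to compound 4 (within the scatter), and the step from 3-aminophenyl to 4-(methylsulfonyl)phenyl reads a number 0.1 percentage points lower from compound 2 to compound 4 (within the scatter), so a substituent in this place does not by itself raise the number, and among the four compounds only compound 3 stands apart. Trifluoromethyl and methylsulfonyl match in heavy-atom count, so that count does not separate them; methylsulfonyl alone brings hydrogen-bond acceptors, but a single pair cannot tie the step to them.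

On these data alone, whether a carboxylic acid, a nitrile or a methoxy group in this place would follow trifluoromethyl or methylsulfonyl stays open, as does any separation among compounds 1, 2 and 4 at other concentrations. Nothing measured here accounts for the gap between the two groups.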